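Cytotoxicity of a sulfonyl indole series: an acyl sulfonamide

The source may report more compounds than this note shows. Statements on the series, on what has been measured and on what is new or still open speak of the compounds shown alone.

Compound 1: `Cc1cc(C)cc(S(=O)(=O)c2c(C(=O)N[C@@H]3CCN(Cc4n[nH]c(=O)n4C)C3)[nH]c3ccc(Cl)cc23)c1` — 22400 nM
Compound 2: `Cc1cc(C)cc(S(=O)(=O)c2c(C(=O)N[C@@H]3CCN(S(C)(=O)=O)C3)[nH]c3ccc(Cl)cc23)c1` — 24000 nM

Of the compounds shown here, two have been measured in an ADME assay on MT4 cells (Homo sapiens) for cytotoxicity, read by MTT assay, with a stated time of 5 days; on this read-out lower numbers stand for higher toxicity in this test and higher numbers for lower toxicity in this test. Compound 1 gives 22400 nM there, and compound 2 gives 24000 nM. For the measured compounds named here, the single step between them, a 1.1-fold higher number from compound 1 to compound 2 (0.03 log units; within the scatter), places the two compounds within the scatter of each other, so neither can be set apart from the other on this read-out.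

Compound 3, `Cc1cc(C)cc(S(=O)(=O)c2c(C(=O)NS(=O)(=O)c3ccc(F)cc3)[nH]c3ccc(Cl)cc23)c1`, differs from compound 2 by (4-fluorophenyl)sulfonyl in place of 1-(methylsulfonyl)pyrrolidin-3-yl on an amide-type nitrogen. This change sits on the amide-type nitrogen whose other neighbour is the carbonyl carbon, a different place from the amine nitrogen in a ring where compound 1 and compound 2 differ. Going by the values given here, no measured step therefore bears on it directly; the only step available, from compound 1 to compound 2, was within the scatter. Compound 3 is expected to stay close to compound 2, with no change at the digits printed from compound 2 to compound 3 (within the scatter) as the expected step. The estimate for compound 3 is 24000 nM, with a range from 8000 nM to 70000 nM.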

Compound 3, half-maximal cytotoxic concentration: > 252000 nM
Compound 3 was reported as a limit (the forecaster's own chance of this, stated with the estimate: 25%); middle value at least 10-fold (1.02 log units) away from the limit.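

For the compounds shown here, the amide-type nitrogen turns out to be a place where this read-out responds strongly, which the earlier compounds could not show, since their only step, a 1.1-fold higher number from compound 1 to compound 2 (0.03 log units; within the scatter), lay on the amine nitrogen in a ring. In this assay, (4-fluorophenyl)sulfonyl in place of 1-(methylsulfonyl)pyrrolidin-3-yl on that nitrogen gives an at least 10-fold higher number from compound 2 to compound 3 (1.02 log units; beyond the scatter), so this change matters far more than the one on the ring nitrogen. The result for compound 3 is a limit of the assay and not a number: the limit of > 252000 nM in this assay, at which 1 of the 3 values shown sits.

The change replaces the whole group at once, so the compounds shown leave open whether the step belongs to the sulfonyl attached to the amide-type nitrogen, to the fluorophenyl ring or to the loss of the pyrrolidine. A benzoyl group or an unsubstituted phenylsulfonyl group on the same nitrogen would separate these parts.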